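Notes on the step from compound 2 to compound 4

The source may hold more compounds than are shown below. What is called first, only, known or untested is meant among the compounds shown, and "the series" means these compounds.

The series shares one core. Compound 1 `Fc1cccc(-c2nc(Nc3ccccc3)c3ccccc3n2)c1` is the plainest member. In a functional assay on U2OS cells (Homo sapiens) for cytotoxicity, read by MTT assay, with a stated time of 48 h (on this read-out higher numbers stand for weaker inhibition and lower numbers for stronger inhibition), compound 1 returns only a limit, > 50000 nM. Compound 2 `Fc1cccc(-c2nc(Nc3ccc(Br)cc3)c3cc(F)ccc3n2)c1` carries a 4-bromophenyl on a nitrogen on an aromatic ring. In this assay compound 2 likewise returns only a limit, > 50000 nM. Compound 3 `Oc1cccc(Nc2nc(-c3cccc(F)c3)nc3ccc(F)cc23)c1` carries a 3-hydroxyphenyl in that place, and in this assay compound 3 gives 33300 nM. Among the compounds with values here, the one measured step, an at least 1.5-fold lower number from compound 2 to compound 3 (0.17 log units; that floor lies within the scatter), starts from a limit and its floor sits within the scatter, so it tells nothing firm about direction. Compound 2 thus stands at the limit of > 50000 nM in this assay, at which 2 of the 3 values shown sit. Compound 4 `Cc1ccccc1Nc1nc(-c2cccc(F)c2)nc2ccc(F)cc12` differs from compound 2 as follows: 2-methylphenyl in place of 4-bromophenyl on a nitrogen on an aromatic ring. Within the data shown here, no measured step covers 2-methylphenyl, and the only step that starts from compound 2, an at least 1.5-fold lower number from compound 2 to compound 3 (0.17 log units; that floor lies within the scatter), gives no ground to expect movement beyond the scatter in this assay. Compound 4 is therefore expected to remain near the limit, which is what a number no higher from compound 2 to compound 4 (the limit leaves the size open) expresses. The estimate for compound 4 in this assay is 50000 nM, in the range 25000 nM to 100000 nM, and a limit rather than a number is the likelier report.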

Compound 4, half-maximal inhibitory concentration: > 50000 nM
Compound 4: a limit, no number (the forecaster's own chance of this, stated with the estimate: 60%); the middle value lies on the limit itself.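

Replacing 4-bromophenyl with 2-methylphenyl on a nitrogen on an aromatic ring gives compound 4 only a limit in this assay, so the step between compound 2 and compound 4 cannot be read. Within the data shown here, compound 2 no longer shares its limit with compound 1 alone, and compound 3 remains the only compound that goes against this clustering: the limit of > 50000 nM in this assay, at which 3 of the 4 values shown sit. Among these compounds, the one readable new step, an at least 1.5-fold higher number from compound 3 to compound 4 (0.17 log units; that floor lies within the scatter), ends on a limit, so it sets no firm direction for 2-methylphenyl against 3-hydroxyphenyl.

The compounds shown leave open whether any group at this place gives a number clearly beyond the scatter of the limit. An aminophenyl, a carboxylic acid on the phenyl ring or a longer chain on the nitrogen would bear on that question.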